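This account rests on a few compounds, and the source may have more. Where it says the series, first, only, none or still open, it means among the compounds named here.

Measured in a functional assay on HL-60 cells (Homo sapiens) for inhibition, read by MTT assay, with a stated time of 72 h; a higher number here means a weaker inhibitor, a lower number a stronger inhibitor:
- compound 1 `CCc1nc(-c2ccccc2F)c(C(=O)N2CCN(c3cccc(Cl)c3)CC2)o1`: 139 nM
- compound 2 `O=C(c1oc(C(F)(F)F)nc1-c1ccccc1F)N1CCN(c2cccc(Cl)c2)CC1`: "not active" (no number reported)
- compound 3 `Cc1nc(-c2ccccc2)c(C(=O)N2CCN(c3cccc(Cl)c3)CC2)o1`: 39.2 nM

Only two of these compounds have numbers. Compound 1, at 139 nM, has the higher number and so is the weaker inhibitor of the two. Compound 3, at 39.2 nM, lies lower, and the gap is beyond the usual scatter. Compound 2 gives no number to compare.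

The next compound is compound 4 `CCc1nc(-c2ccccc2Cl)c(C(=O)N2CCN(c3cccc(Cl)c3)CC2)o1`. It differs from compound 1 by chloro in place of fluoro on an aromatic carbon, ortho to a large group, so 2-fluorophenyl becomes 2-chlorophenyl. Among the compounds with values here, no measured pair shows this change, so the expectation rests on compound 1 at 139 nM alone. No direction is favoured, and the expected step of a 1.1-fold lower number from compound 1 to compound 4 (0.03 log units; within the scatter) stays within the scatter. The estimated value for compound 4 in this assay is 130 nM, with an expected range of 45 nM to 380 nM.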

Compound 4, half-maximal inhibitory concentration: 98.9 nM
For compound 4 the middle estimate is 1.3-fold (0.12 log units) above the measured one, within the range that was stated.
By their numbers in this assay, from the lowest: compound 3; then compounds 4 and 1 (each within the scatter of the next).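

In this assay, within the data shown here, the first readable step is a 1.4-fold lower number from compound 1 to compound 4 (0.15 log units; within the scatter) for 2-fluorophenyl to 2-chlorophenyl. On this aromatic carbon, ortho to a large group, chloro in place of fluoro therefore keeps a measured number, and the size of the step cannot be told apart from the scatter of repeated measurements. No measurement available on these compounds gives a reason for this result.

This single pair leaves open how groups other than the two halogens would read at this place, such as methoxy, a nitrile, an amine or a carboxylic acid. It also leaves open whether chloro and fluoro would still read alike with a longer chain in place of the ethyl group shared by compound 1 and compound 4.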